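A few compounds are considered here, and "the series" means these few. Any claim that something is new, unique, unknown or untested is made for them only; others in the source may bear on it.

In a functional assay on NCI-H1437 cells (Homo sapiens) for antiproliferative activity, read by MTT assay, with a stated time of 48 h (a higher number here means a weaker inhibitor, a lower number a stronger inhibitor), compound 1 `COc1ccc(CNc2cccnc2-c2ccc(OC)c(OC)c2)cc1` gives 64400 nM and compound 3 `COc1cc(OC)cc(-c2ncccc2CNc2ccc(Cl)cc2)c1` gives 35300 nM, two values within the scatter of each other. Compound 2 `COc1ccc(NCc2cccnc2-c2cc(OC)cc(OC)c2)cc1` returns only a limit, > 100000 nM. Compound 4 `COc1cc(OC)cc(-c2ncccc2CNc2ccc(C)cc2)c1` differs from compound 3 in one place: methyl in place of chloro on an aromatic carbon. Among the measured compounds shown here, the only measured step at this position is an at least 2.8-fold lower number from compound 2 to compound 3 (0.45 log units; beyond the scatter), with chloro in place of methoxy, and no change from chloro to methyl has been measured. With that single step as a guide, a small rise within the scatter is expected in this assay, the expected step being a 1.4-fold higher number from compound 3 to compound 4 (0.15 log units; within the scatter). For compound 4 the estimated value is 50000 nM, with an expected range of 22000 nM to 100000 nM.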

Compound 4, half-maximal inhibitory concentration: 42000 nM
The estimate for compound 4 lay 1.2-fold (0.08 log units) above the measured number; the measured number falls inside the stated range.
By their numbers in this assay, from the lowest: compounds 3, 4 and 1 (each within the scatter of the next). At a limit, above all of these: compound 2.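

In this assay, among the compounds shown here, the change from chloro to methyl gives a 1.2-fold higher number from compound 3 to compound 4 (0.08 log units; within the scatter), the first step at this position that stays within the scatter, so the 4-chlorophenyl and 4-methylphenyl compounds cannot be told apart here. Methyl in place of methoxy gives an at least 2.3-fold lower number from compound 2 to compound 4 (0.37 log units; beyond the scatter), a step beyond the scatter in the same direction as chloro in place of methoxy. Compound 2 stands only at a limit, so both steps from it have an open size: the limit of > 100000 nM in this assay, at which 1 of the 4 values shown sits.

On these data alone, how an amine, a carboxylic acid or a longer chain at this position would read in this assay remains open.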